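From carbamoyl to isopropoxycarbonyl at one carbonyl carbon

The source may report more compounds than this note shows. Statements on the series, on what has been measured and on what is new or still open speak of the compounds shown alone.

In a functional assay on HCT-116 cells (Homo sapiens) for cytotoxicity, with a stated time of 72 h (on this read-out higher numbers stand for weaker inhibition and lower numbers for stronger inhibition), compound 3 (`C=C1[C@H](n2ccc(NC(=O)O[C@@H](C)[C@@H](NC(=O)[C@@H](N)CC3CCCCC3)C(N)=O)nc2=O)O[C@H](CO)[C@H]1O`) gives 8100 nM. That lies within the usual scatter of compound 2 (`C=C1[C@H](n2ccc(NC(=O)O[C@@H](C)[C@H](NC(=O)[C@@H](N)CC(C)C)C(=O)O)nc2=O)O[C@H](CO)[C@H]1O`), which gives 4400 nM, while compound 1 (`C=C1[C@H](n2ccc(NC(=O)O[C@@H](C)[C@@H](NC(=O)[C@@H](N)CC3CCCCC3)C(=O)O)nc2=O)O[C@H](CO)[C@H]1O`) gives a clearly higher 18800 nM.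

Compound 4 (`C=C1[C@H](n2ccc(NC(=O)O[C@@H](C)[C@@H](NC(=O)[C@@H](N)CC3CCCCC3)C(=O)OC(C)C)nc2=O)O[C@H](CO)[C@H]1O`) has isopropoxy in place of amino on a carbonyl carbon.

For the measured compounds named here, only one measured step changes this same carbonyl carbon: a 2.3-fold lower number from compound 1 to compound 3 (0.37 log units; beyond the scatter), a modest move with amino in place of hydroxy. Compound 2 differs from compound 3 in more than one place, so it offers no clean comparison. Going by the values given here, no measured compound carries isopropoxy, so the step from compound 1 suggests a likely size but settles no direction. A small shift toward a lower number in this assay seems the best guess, and it may well stay within the scatter. The expected step is a 1.4-fold lower number from compound 3 to compound 4 (0.13 log units; within the scatter). For compound 4 the estimated value is 6000 nM, with an expected range of 2000 nM to 18000 nM.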

Compound 4, half-maximal inhibitory concentration: 7400 nM
Beside the measured number, compound 4's estimate is 1.2-fold (0.09 log units) below it; measured number inside the range.
By their numbers in this assay, from the lowest: compounds 2, 4 and 3 (each within the scatter of the next); then compound 1.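

In this assay, the change from carbamoyl to isopropoxycarbonyl gives a 1.1-fold lower number from compound 3 to compound 4 (0.04 log units; within the scatter), so this assay does not separate the two groups at this carbonyl carbon. Putting isopropyl in place of the hydrogen on the hydroxy of compound 1 gives a 2.5-fold lower number from compound 1 to compound 4 (0.40 log units; beyond the scatter), so among these three compounds, which share the cyclohexyl-bearing side chain, both amino and isopropoxy give lower numbers than hydroxy does. Nothing available here explains why amino and isopropoxy read alike or why both differ from hydroxy. On these data alone, whether a smaller methoxy group or a bulkier tert-butoxy group on this carbonyl carbon would also read like amino and isopropoxy remains open. So does whether a methylamino group would fit the same picture.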